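The compounds below may be only part of what the source reports. "The series", "measured", "known", "first", "only" and "open" are said of these compounds alone.

Notes on the series. Compound 1 `COc1ccc(-c2ccc3c(NCCCNCc4cccc(OC)c4O)ccnc3c2)cc1` stands level with compound 3 `COc1ccc(-c2ccc3c(NCCCNCc4cc(F)ccc4OC)ccnc3c2)cc1` in a physicochemical assay for acid dissociation, the two together giving the highest of the three numbers: compound 1 gives 9.47 and compound 3 gives 9.47, with no change at the digits printed from compound 1 to compound 3 (within the scatter). Compound 2 `COc1ccc(F)cc1CNCCCNc1ccnc2cc(Oc3cccc(N(C)C)c3)ccc12` gives 9.28, and a number 0.19 log units higher from compound 2 to compound 3 (within the scatter).

Compound 4 `COc1cccc(CNCCCNc2ccnc3cc(Cc4ccc(C#N)cc4)ccc23)c1O` is not yet measured. It differs from compound 1 in one place: 4-cyanobenzyl in place of 4-methoxyphenyl on an aromatic carbon.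

Of the two measured steps, the one that bears on this change is the exchange on the same aromatic carbon of the core, where a number 0.19 log units higher from compound 2 to compound 3 (within the scatter), a step inside the scatter. The other measured step, no change at the digits printed from compound 1 to compound 3 (within the scatter), alters the group on the saturated chain carbon bound to the amine nitrogen and is likewise inside the scatter; it does not touch the position changed here. Both steps suggest the read-out is little moved by exchanges at either place over the range sampled, though three compounds allow no firm pattern. For compound 4 the expected step is accordingly a number 0.07 log units lower from compound 1 to compound 4 (within the scatter), nothing beyond the scatter. Compound 4 is estimated at 9.4, with a range from 9.1 to 9.7.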

Compound 4, acid dissociation constant: 9.47
Compound 4: middle estimate off by 0.07 log units, on the low side; measured number inside the range.
By their numbers in this assay, from the lowest: compounds 2, 1, 3 and 4 (each within the scatter of the next).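

In this assay the exchange on this aromatic carbon gives no change at the digits printed from compound 1 to compound 4 (within the scatter), so with the 2-hydroxy-3-methoxyphenyl group held on the chain, this position again shows no step beyond the scatter. The earlier step at this carbon, a number 0.19 log units higher from compound 2 to compound 3 (within the scatter), compared 3-(dimethylamino)phenoxy with 4-methoxyphenyl on the 5-fluoro-2-methoxyphenyl background; the new pair extends the same flat reading to 4-cyanobenzyl, which brings a triple bond outside aromatic rings that 4-methoxyphenyl lacks, and none of the three groups sampled here goes against it. Nothing available accounts for this flat reading.

Whether a primary amine or a carboxylic acid on this aromatic carbon would move the number beyond the scatter remains open, since all three groups shown here carry a six-membered aromatic ring of carbon only. Also open, on these data alone, is the effect of a longer chain between the two nitrogens of the shared core's side chain, a part of the structure that stays the same in all four compounds.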